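This account rests on a few compounds, and the source may have more. Where it says the series, first, only, none or still open, it means among the compounds named here.

Of the compounds shown here, three sharing one core have been measured in an assay for binding affinity to dual specificity mitogen-activated protein kinase kinase 4 (Homo sapiens), read by KINOMEscan, tested at 100 nM; on this read-out higher numbers stand for a weaker effect at the one concentration tested and lower numbers for a stronger effect. Compound 1, `CCCS(=O)(=O)Nc1ccc(F)c(C(=O)c2n[nH]c3ncc(-c4cccc(N(C)C)c4)cc23)c1F`, gives 26%, which is the highest of the three numbers, so in this set it is the weakest binder. Compound 2, `CCCS(=O)(=O)Nc1ccc(F)c(C(=O)c2n[nH]c3ncc(-c4ccc(Cl)c(C(F)(F)F)c4)cc23)c1F`, gives 15%, and compound 3, `CCCS(=O)(=O)Nc1ccc(F)c(C(=O)c2n[nH]c3ncc(-c4ccc(S(=O)(=O)NC)cc4)cc23)c1F`, gives 1.2%. Both steps away from compound 1 go beyond the scatter: a number 11 percentage points lower from compound 1 to compound 2 (beyond the scatter) and a number 24.8 percentage points lower from compound 1 to compound 3 (beyond the scatter). The step of a number 13.8 percentage points lower from compound 2 to compound 3 (beyond the scatter) is also beyond the scatter.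

Compound 4, `CCCS(=O)(=O)Nc1ccc(F)c(C(=O)c2n[nH]c3ncc(-c4ccc(S(N)(=O)=O)cc4Cl)cc23)c1F`, has not yet been measured. It differs from compound 1 in one place: 2-chloro-4-sulfamoylphenyl in place of 3-(dimethylamino)phenyl on an aromatic carbon. The entering group carries a chlorine, as the entering group of compound 2 does, and a sulfamoyl group, a near relative of the methylsulfamoyl group of compound 3. Both of those changes lowered the number from compound 1, the sulfonamide-bearing one by the larger amount. A drop beyond the scatter is therefore expected, of a size near the step to compound 3: the expected step is a number 22 percentage points lower from compound 1 to compound 4 (beyond the scatter). Compound 4 is estimated to give 4% in this assay, with a range from 0.5% to 15%.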

Compound 4, a percentage reported as activity, at one concentration (the size of the read-out at that concentration, not a potency): 3.4%
Beside the measured number, compound 4's estimate is 0.6 percentage points above it; the measured number falls inside the stated range.
By their numbers in this assay, from the lowest: compounds 3 and 4 (each within the scatter of the next); then compound 2; then compound 1.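

In this assay, this position on the shared core accepts 2-chloro-4-sulfamoylphenyl with a number 22.6 percentage points lower from compound 1 to compound 4 (beyond the scatter), and the same entering group gives a number 11.6 percentage points lower from compound 2 to compound 4 (beyond the scatter), so a chlorine on the ring does not by itself hold the number at the level of compound 2. The new group also gives a number 2.2 percentage points higher from compound 3 to compound 4 (within the scatter), which shows that a low number here does not depend on keeping the methyl of the methylsulfamoyl group, and that compounds 3 and 4, the two whose rings carry these sulfonyl-based groups, both sit below compounds 1 and 2. Nothing available explains why these entering groups give lower numbers than the other two.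

From the compounds shown here alone, compound 4 differs from compound 3 by both a chlorine and a missing methyl, so the share of each stays unknown until the same ring is seen without its chlorine. Also open, going by these compounds, is whether a carboxylic acid in place of the sulfamoyl group would give a number as low as those of compounds 3 and 4.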